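Shifting a methoxy group on the ring-nitrogen aryl substituent

This account rests on a few compounds, and the source may have more. Where it says the series, first, only, none or still open, it means among the compounds named here.

In a functional assay on HOS-TE85 cells (Homo sapiens) for inhibition, read by CCK-8 assay, with a stated time of 72 h (on this read-out lower numbers stand for stronger inhibition and higher numbers for weaker inhibition), compound 1 `COc1ccc(OC)c(N2C(=O)CSC2c2cccc(C(=O)NCCCCc3ccccc3)c2)c1` gives > 1000 nM, a limit of the assay rather than a number. Compound 1 thus sits at the limit of > 1000 nM in this assay, at which 1 of the 3 values shown sits. The two further measured compounds carry a pyrazole-ended chain on the amide: compound 2 `Cc1ccnc(N2C(=O)CS[C@@H]2c2cccc(C(=O)NCCCCn3cccn3)c2)c1` gives 21.9 nM in this assay, and compound 3 `O=C(NCCCCn1cccn1)c1cccc(C2SCC(=O)N2c2cccc(C3CC3)c2)c1` gives 299 nM. The unmeasured compound 4 `COc1ccc(N2C(=O)CSC2c2cccc(C(=O)NCCCCc3ccccc3)c2)c(OC)c1` differs from compound 1 in one place: 2,4-dimethoxyphenyl in place of 2,5-dimethoxyphenyl on an amide-type nitrogen in a ring. For the measured compounds named here, no measured pair shows the effect of this change, so no shift beyond the usual scatter in this assay is expected in either direction. Compound 4 is therefore estimated at 1500 nM, within 400 nM to 6000 nM. The implied step that the limit leaves unreadable from compound 1 to compound 4 is expected to be small.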

Compound 4, half-maximal inhibitory concentration: 90.4 nM
Compound 4: middle estimate off by 17-fold (1.22 log units), on the high side, outside the stated range (below it).
By their numbers in this assay, from the lowest: compound 2; then compound 4; then compound 3. At a limit, above all of these: compound 1.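

Swapping 2,5-dimethoxyphenyl for 2,4-dimethoxyphenyl on an amide-type nitrogen in a ring, with the atoms and counts unchanged, gives an at least 11-fold lower number from compound 1 to compound 4 (1.04 log units; beyond the scatter) in this assay. For the compounds shown here, this is the first sign that the arrangement of the methoxy groups at this place matters on the phenyl-ended chain. Compound 1 stands at a limit of the assay, so the full size of the step cannot be read: the limit of > 1000 nM in this assay, at which 1 of the 4 values shown sits.

Going by these compounds, whether 2,4-dimethoxyphenyl would act alike with the pyrazole-ended chain of compound 2 and compound 3 remains open. So does how a single methoxy group or a chlorine would fare at this place.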